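The source may report more compounds than this note shows. Statements on the series, on what has been measured and on what is new or still open speak of the compounds shown alone.

Measured so far in a functional assay on a cell-free system (Platelet, plasma, Oryctolagus cuniculus) for inhibition, with a stated time of 5 min; a higher number here means a weaker inhibitor, a lower number a stronger inhibitor:
- compound 1 `CCOC(=O)/C=C/c1cccc(OCc2nc(C)c(C)nc2C)c1` gives (628000 nM)
- compound 2 `Cc1nc(C)c(COc2ccc(/C=C/C(=O)O)cc2)nc1C` gives (1400000 nM)

Compound 1 holds the lower of the two numbers, so it is the stronger inhibitor, and its gap to compound 2 lies beyond the usual scatter.

Compound 3 `Cc1nc(C)c(COc2cccc(/C=C/C(=O)O)c2)nc1C` follows from compound 1 with hydrogen in place of ethyl on an oxygen next to a carbonyl group. This reads as ethoxycarbonyl to carboxy.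

Within the data shown here, no measured pair shows this change alone. In this assay a small move towards a higher number is expected, possibly none beyond the scatter. Among the measured compounds shown here, the one measured compound with a 2-carboxyethenyl group, compound 2 (1400000 nM), is the basis for that direction. The estimated change is the step (a 1.4-fold higher number from compound 1 to compound 3 (0.16 log units; within the scatter)) and no larger shift is expected. Compound 3 is expected at (900000 nM), with an estimated range of (350000 nM) to (2300000 nM).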

Compound 3, half-maximal inhibitory concentration: 161000 nM
Compound 3: middle estimate off by 5.6-fold (0.75 log units), on the high side; measured number outside the range, below it.
By their numbers in this assay, from the lowest: compound 3; then compound 1; then compound 2.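

In this assay the step from ethoxycarbonyl to carboxy, with hydrogen in place of ethyl on an oxygen next to a carbonyl group, gives a 3.9-fold lower number from compound 1 to compound 3 (0.59 log units; beyond the scatter) in favour of the carboxy form, so this position responds to the change. Among these compounds, compound 2 also carries a 2-carboxyethenyl group and gives 1400000 nM in this assay, while compound 3 gives 161000 nM as the lowest number so far, so the group alone does not set the number. No measurement at hand bears on the origin of this step.

On these data alone, whether a methyl ester or a primary amide in this place would read closer to compound 1 or to compound 3 remains open. Also open, as far as these compounds go, is whether a longer chain between the core and the carboxy group would lower the number further.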